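The compounds below may be only part of what the source reports. "The series", "measured", "known", "first", "only" and "open" are said of these compounds alone.

Measured so far in a functional assay on K562 cells (Homo sapiens) for antiproliferative activity, read by MTT assay, with a stated time of 6 days; on this read-out lower numbers stand for stronger inhibition and higher numbers for weaker inhibition:

compound 1 `O=C1C=C[C@@H](OCc2ccccc2)[C@@H]([C@@H](COC(=O)/C=C/c2ccccc2)OCc2ccccc2)O1`: 1590 nM
compound 2 `CC(=O)O[C@@H]1C=CC(=O)O[C@@H]1[C@@H](COC(=O)/C=C/c1ccc([N+](=O)[O-])cc1)OC(C)=O`: 2340 nM

Compound 1 and compound 2 share the unsaturated lactone core but differ at several positions at once, so no single step can be read between them; their two values in this assay sit within the usual scatter of each other, and neither stands apart.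

Compound 3 `CC(=O)OC[C@@H](OCc1ccccc1)[C@H]1OC(=O)C=C[C@H]1OCc1ccccc1` is not yet measured. Against compound 1 it carries one change, (methyl in place of 2-phenylethenyl on a carbonyl carbon). For the measured compounds named here, no measured pair isolates this exchange, so its effect is not known from the data. The number for compound 3 in this assay is expected to be somewhat higher than for compound 1, with a step of a 1.9-fold higher number from compound 1 to compound 3 (0.28 log units; within the scatter) that lies near the edge of the scatter rather than clearly beyond it. For compound 3 the estimate in this assay is 3000 nM, within a range from 1200 nM to 8000 nM.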

Compound 3, half-maximal inhibitory concentration: 880 nM
Estimate against measurement, compound 3: 3.4-fold (0.53 log units) above; the measured number lies below the stated range.
By their numbers in this assay, from the lowest: compounds 3, 1 and 2 (each within the scatter of the next, the first and the last beyond it).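

In this assay, methyl in place of 2-phenylethenyl on a carbonyl carbon gives a 1.8-fold lower number from compound 1 to compound 3 (0.26 log units; within the scatter) and so leaves compound 1 and compound 3 not separated by this read-out. For this pair, the six-membered aromatic ring and the double bond of the 2-phenylethenyl group are therefore not needed to keep the number within the scatter, even though only methyl remains at this place. No measured evidence bears on the reason for this result.

Compound 2 differs from compound 1 and compound 3 in several places, so its steps cannot be read. On these data alone, whether this place also accepts a longer alkyl chain, or a group carrying an amine or a carboxylic acid, remains open, as does whether the same exchange gives a similar result on another core.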